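The compounds below may be only part of what the source reports. "The series", "measured", "known", "first", "only" and "open" are said of these compounds alone.

Working notes on an in vitro ADME assay on microsomes from liver (Homo sapiens) for metabolic stability; a higher number here means faster removal of the compound, a lower number slower removal. Three measured compounds share one core and differ in the aromatic group on a saturated chain carbon bound to an oxygen on a saturated carbon. Compound 1 `O=C(COCc1cccnc1)N1CCN(c2ccc(Cl)cc2Cl)CC1` gives 210 mL.min-1.g-1, compound 2 `O=C(COCc1ncccn1)N1CCN(c2ccc(Cl)cc2Cl)CC1` gives 16 mL.min-1.g-1 and compound 3 `O=C(COCc1cncs1)N1CCN(c2ccc(Cl)cc2Cl)CC1` gives 73 mL.min-1.g-1, so compound 3 is the second highest of the three.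

Compound 4 `N#Cc1ccc(COCC(=O)N2CCN(c3ccc(Cl)cc3Cl)CC2)s1` has not yet been measured. It differs from compound 3 as follows: 5-cyanothiophen-2-yl in place of 1,3-thiazol-5-yl on a saturated chain carbon bound to an oxygen on a saturated carbon. In words, 5-cyanothiophen-2-yl stands in place of 1,3-thiazol-5-yl at that same place.

All three measured steps change the group at this place, and all lie beyond the scatter. The modest ones are a 2.9-fold lower number from compound 1 to compound 3 (0.46 log units; beyond the scatter) and a 4.6-fold higher number from compound 2 to compound 3 (0.66 log units; beyond the scatter), while the large one is a 13-fold lower number from compound 1 to compound 2 (1.12 log units; beyond the scatter). Within the data shown here, this place therefore responds to the choice of group, but none of the measured compounds carries 5-cyanothiophen-2-yl, and the direction of the change remains open. Compound 3 carries the only five-membered aromatic ring among the measured compounds, so its 73 mL.min-1.g-1 serves as the anchor. The expected change is a 1.2-fold lower number from compound 3 to compound 4 (0.09 log units; within the scatter), with no step beyond the scatter as the central expectation, although a modest step either way remains possible.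

For compound 4 the estimated value is 60 mL.min-1.g-1, with an expected range from 22 mL.min-1.g-1 to 170 mL.min-1.g-1.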

Compound 4, intrinsic clearance in microsomes: 110 mL.min-1.g-1
Compound 4: the middle estimate sits 1.8-fold (0.26 log units) below what was measured; the range from low to high includes it.
By their numbers in this assay, from the lowest: compound 2; then compounds 3, 4 and 1 (each within the scatter of the next, the first and the last beyond it).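

In this assay, 5-cyanothiophen-2-yl in place of 1,3-thiazol-5-yl gives no step beyond the scatter (a 1.5-fold higher number from compound 3 to compound 4 (0.18 log units; within the scatter)), so this position accepts the larger group with a triple bond without a separable change from the thiazole compound. Among these compounds, the same group also stays within the scatter of pyridin-3-yl (a 1.9-fold lower number from compound 1 to compound 4 (0.28 log units; within the scatter)) but lies beyond it against pyrimidin-2-yl (a 6.9-fold higher number from compound 2 to compound 4 (0.84 log units; beyond the scatter)), which leaves compound 2 as the only compound with the lowest number beyond the scatter of all three others, while compound 4 cannot be ranked against compound 1 or compound 3. No measurement in hand gives a cause for any of these steps.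

The compounds shown leave open how the step divides between the change of ring and the nitrile, which an unsubstituted thiophen-2-yl at the same place would help to separate. Going by these compounds, it also remains open whether the low number of compound 2 belongs to pyrimidin-2-yl alone or extends to another six-membered ring with two nitrogens, such as pyrazin-2-yl.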